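The compounds below may be only part of what the source reports. "The series", "measured", "known", "first", "only" and "open" are said of these compounds alone.

Measured so far:
compound 1, `O=c1[nH]c2ccccc2oc1=O`: 42000 nM
compound 2, `COc1cccc2[nH]c(=O)c(=O)oc12`: 7000 nM
compound 3, `COc1ccc2[nH]c(=O)c(=O)oc2c1`: 28000 nM

In a functional assay with Rattus norvegicus as the target (on this read-out lower numbers stand for stronger inhibition and higher numbers for weaker inhibition), compound 1 gives the highest number of the three. Compound 3 lies nearest to it, and a 1.5-fold lower number from compound 1 to compound 3 (0.18 log units; within the scatter) stays within the scatter; compound 2 lies furthest, and a 6.0-fold lower number from compound 1 to compound 2 (0.78 log units; beyond the scatter) is a modest step beyond the scatter. Compound 4, `N#Cc1ccc2[nH]c(=O)c(=O)oc2c1`, is not yet measured. It differs from compound 1 in one place: cyano in place of hydrogen on an aromatic carbon. Both measured steps concern a methoxy in place of hydrogen on an aromatic carbon, not a cyano, so neither bears directly on the new group; the shared core is otherwise the same. The step of methoxy on the aromatic carbon of compound 3 was small, that of compound 2 modest, and nothing here tells whether a cyano would follow either. Compound 4 is therefore expected near compound 1, with a 1.4-fold lower number from compound 1 to compound 4 (0.15 log units; within the scatter) as the estimated step, within the scatter. The estimate for compound 4 in this assay is 30000 nM, ranging from 8000 nM to 110000 nM.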

Compound 4, half-maximal inhibitory concentration: 15000 nM
Compound 4: middle estimate off by 2.0-fold (0.30 log units), on the high side; the range from low to high includes it.
By their numbers in this assay, from the lowest: compound 2; then compounds 4, 3 and 1 (each within the scatter of the next, the first and the last beyond it).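

In this assay, cyano in place of hydrogen on this aromatic carbon, meta to a fused ring and para to a fused ring, gives a modest step beyond the scatter (a 2.8-fold lower number from compound 1 to compound 4 (0.45 log units; beyond the scatter)), whereas methoxy on the same carbon stayed within it (a 1.5-fold lower number from compound 1 to compound 3 (0.18 log units; within the scatter)). Yet cyano in place of methoxy gives a 1.9-fold lower number from compound 3 to compound 4 (0.27 log units; within the scatter) and so does not separate the two groups at this carbon. Nothing measured here explains either step.

The compounds shown leave open whether an amine or a carboxylic acid on this carbon would give a step of similar size. They also leave open how cyano would behave on the carbon that carries the methoxy in compound 2, where methoxy gave a 6.0-fold lower number from compound 1 to compound 2 (0.78 log units; beyond the scatter) as its step.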